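A few compounds are considered here, and "the series" means these few. Any claim that something is new, unique, unknown or untested is made for them only; others in the source may bear on it.

Compound 1 `O=C(Nc1ccc2c(c1)B(O)OC2)c1ccccc1C(F)(F)F`: 4400 nM
Compound 2 `O=C(Nc1ccc2c(c1)B(O)OC2)c1ccccc1F`: > 10000 nM (a limit, not a number)

Both compounds were tested in a functional assay on PBMC cells (Homo sapiens) for inhibition, read by HTRF, with stated times of 15 min and 24 h; on this read-out higher numbers stand for weaker inhibition and lower numbers for stronger inhibition. Compound 2 has no exact number on this read-out, only the limit > 10000 nM.

Compound 3 `O=C(Nc1ccc2c(c1)B(O)OC2)c1c(F)cccc1C(F)(F)F` keeps everything in compound 2 and adds one group: trifluoromethyl in place of hydrogen on an aromatic carbon. In words, trifluoromethyl stands in place of hydrogen on an aromatic carbon.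

Among the compounds with values here, one measured step bears on this change: an at least 2.2-fold higher number from compound 1 to compound 2 (0.35 log units; beyond the scatter), with fluoro in place of trifluoromethyl on an aromatic carbon. Compound 3 regains the trifluoromethyl lost in that step and also keeps the fluoro, so a move towards lower numbers is expected, of about that size or larger. Within the data shown here, no measured compound carries both groups, which leaves the size uncertain.

The expected change is an at least 3.3-fold lower number from compound 2 to compound 3 (0.52 log units; beyond the scatter). For compound 3 the estimated value is 3000 nM, with an expected range of 800 nM to 10000 nM.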

Compound 3, half-maximal inhibitory concentration: 370 nM
The estimate for compound 3 lay 8.1-fold (0.91 log units) above the measured number; measured number below the stated range.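

In this assay, trifluoromethyl in place of hydrogen on this aromatic carbon, with the fluoro kept, gives an at least 27-fold lower number from compound 2 to compound 3 (1.43 log units; beyond the scatter). Within the data shown here, the fluoro also counts once trifluoromethyl is present, a contribution the earlier compounds could not show: fluoro in place of hydrogen on an aromatic carbon gives a 12-fold lower number from compound 1 to compound 3 (1.08 log units; beyond the scatter). The first of these steps is only a minimum, since compound 2 has a limit and not a number: the limit of > 10000 nM in this assay, at which 1 of the 3 values shown sits.

From the compounds shown here alone, whether the two groups simply add together or reinforce each other stays open, as the full size of the first step is unknown. The compounds shown also leave open whether the gain is specific to trifluoromethyl or would also appear with a chloro group, a methoxy group or an amine at this place.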